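The source may report more compounds than this note shows. Statements on the series, on what has been measured and on what is new or still open speak of the compounds shown alone.

Measured so far in an assay on isolated protein for inhibition of thyroid hormone receptor alpha (Homo sapiens), read by fluorescence polarization; a higher number here means a weaker inhibitor, a lower number a stronger inhibitor:
Compound 1 `CS(=O)(=O)c1ccc(C(=O)NCCC(=O)N2CCc3ccccc32)cc1[N+](=O)[O-]` gives > 60000 nM, which is a limit of the assay and not a number.
Compound 2 `CN(CC(=O)N1CCN(c2ccc(F)cc2)CC1)C(=O)c1ccc(S(C)(=O)=O)c([N+](=O)[O-])c1` gives > 60000 nM, again a limit of the assay.
Compound 3 `CS(=O)(=O)c1ccc(C(=O)NCCCC(=O)N2Cc3ccccc3C2)cc1[N+](=O)[O-]` gives > 60000 nM, also a limit of the assay.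

Compound 2 therefore stands nowhere on a numerical scale: its reading is a limit, and the same holds for the two other compounds, as summarised by the limit of > 60000 nM in this assay, at which 3 of the 3 values shown sit. For the measured compounds named here, no two of the measured compounds differ in one place, so no measured step is available in this assay, and nothing so far distinguishes one of the three cores from another.

Compound 4 `CN(CC(=O)N1CCN(c2ccccc2)CC1)C(=O)c1ccc(S(C)(=O)=O)c([N+](=O)[O-])c1` differs from compound 2 by hydrogen in place of fluoro on an aromatic carbon, para to a large group; cut one bond further out, 4-fluorophenyl becomes phenyl. For this step in this assay no shift beyond the scatter is expected in either direction, since compound 2 itself is known only as a limit and the whole series sits at that limit. For compound 4 the estimate is 100000 nM, with a range from 30000 nM to 400000 nM, and the step from compound 2 to compound 4 is expected to be a step that the limit leaves unreadable from compound 2 to compound 4; most likely compound 4 will again return only a limit.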

Compound 4, half-maximal inhibitory concentration: > 60000 nM
Compound 4 was reported as a limit (the forecaster's own chance of this, stated with the estimate: 90%); the middle value does not contradict the limit.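

Compound 2 and compound 4 both return only limits of the assay and not numbers, so the step from fluoro to hydrogen cannot be read: the limit of > 60000 nM in this assay, at which 4 of the 4 values shown sit.

The compounds shown leave open whether hydrogen or fluoro at this aromatic carbon makes any difference in this assay, and how the cores of compound 1, compound 2 and compound 3 rank.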